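Methoxy in place of fluoro: compound 2 to compound 3

The source may report more compounds than this note shows. Statements on the series, on what has been measured and on what is new or still open speak of the compounds shown alone.

Measured so far:
compound 1 `C#CCSc1nc(NCCC#N)c2ccncc2n1` gives > 80000 nM in a functional assay on HepG2 cells (Homo sapiens) for inhibition, read by MTT assay, with a stated time of 72 h; a higher number here means a weaker inhibitor, a lower number a stronger inhibitor; this is a limit of the assay, not a number.
compound 2 `C#CCSc1nc(Nc2ccc(F)cc2)c2ccncc2n1` gives 10800 nM in this assay.

Within the data shown here, compound 2 therefore holds the only number so far in this assay; the other entry, for compound 1, is the limit (the limit of > 80000 nM in this assay, at which 1 of the 2 values shown sits). Among the measured compounds shown here, the single measured step, an at least 7.4-fold lower number from compound 1 to compound 2 (0.86 log units; beyond the scatter), changes the group on the ring nitrogen, not the substituent on the fluorophenyl ring.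

Compound 3 `C#CCSc1nc(Nc2ccc(OC)cc2)c2ccncc2n1` differs from compound 2 by methoxy in place of fluoro on an aromatic carbon. For the measured compounds named here, no measured step touches this position, so the step from compound 1 to compound 2 gives no direct guide. With nothing pointing either way, the expected step is a 1.1-fold higher number from compound 2 to compound 3 (0.05 log units; within the scatter), within the usual scatter. Compound 3 is estimated at 12000 nM in this assay, with a range from 5000 nM to 30000 nM.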

Compound 3, half-maximal inhibitory concentration: > 80000 nM
Compound 3: a limit, no number; the forecaster's own chance of this, stated with the estimate: 10%; at least 6.6-fold (0.82 log units) between middle value and limit.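

Methoxy in place of fluoro on an aromatic carbon, para to a large group, is not a neutral change in this assay: the step shows an at least 7.4-fold higher number from compound 2 to compound 3 (0.86 log units; beyond the scatter). Compound 3 gives > 80000 nM, which is a limit and not a number, and it sits at the same limit as compound 1: the limit of > 80000 nM in this assay, at which 2 of the 3 values shown sit. Among these compounds, the earlier step changed only the group on the nitrogen, so this is the first reading at this position, and it shows that activity here depends on the substituent on the ring as well as on that nitrogen group.

On these data alone, the true size of the step remains open, since only one end of it is a number. Also open, as far as these compounds go, is whether an amine, a chloro group or a longer alkoxy chain at this position would stay near compound 2 or fall to the same limit.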